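Compound 1 Gains a Methyl on an Aromatic Carbon

The source may hold more compounds than are shown below. What is called first, only, known or untested is meant among the compounds shown, and "the series" means these compounds.

Compound 1 `OCc1cn(Cc2ccccc2)c2ccccc12` was tested in an ADME assay on T29 cells (Homo sapiens) for cytotoxicity, read by sulforhodamine B assay, with a stated time of 3 days (on this read-out lower numbers stand for stronger inhibition and higher numbers for weaker inhibition), where compound 1 gives 14500 nM. That is the only number shown for this pair of measured compounds, so compound 1 stands as the single firm value; the other result is a limit. Compound 2 `OCc1cn(Cc2ccc(Cl)cc2)c2ccccc12` differs from compound 1 by a chloro in place of hydrogen on an aromatic carbon. In this assay compound 2 gives > 31600 nM, which is a limit of the assay and not a number. The step of an at least 2.1-fold higher number from compound 1 to compound 2 (0.33 log units; beyond the scatter) is therefore at least modest and runs toward weaker inhibition, as set by the limit of > 31600 nM in this assay, at which 1 of the 2 values shown sits.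

Compound 3 `Cc1cccc(Cn2cc(CO)c3ccccc32)c1` has not yet been measured. It differs from compound 1 by methyl in place of hydrogen on an aromatic carbon. No measured step involves a methyl; the single step shown, from the chloro, points toward weaker inhibition and sits at a different place. A small shift toward a higher number, or none beyond the scatter, is expected. The estimate for compound 3 in this assay is 20000 nM, between 8000 nM and 50000 nM, meaning an expected step of a 1.4-fold higher number from compound 1 to compound 3 (0.14 log units; within the scatter).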

Compound 3, half-maximal inhibitory concentration: > 31600 nM
Compound 3: no number, only a limit (the forecaster's own chance of this, stated with the estimate: 30%); middle value at least 1.5-fold (0.19 log units) away from the limit.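

The change to a methyl gives an at least 2.1-fold higher number from compound 1 to compound 3 (0.33 log units; beyond the scatter), so even this small group, on an aromatic carbon of the six-membered aromatic ring and meta to a large group, moves the read-out in this assay toward weaker inhibition. With the chloro of compound 2 the earlier step went the same way, and the shift is now seen with a second group, although at a place that need not be the same. Compound 3 gives a limit of the assay and not a number, so the step has a lower bound only, and its true size cannot be read: the limit of > 31600 nM in this assay, at which 2 of the 3 values shown sit.

From the compounds shown here alone, what remains open is how far compound 2 and compound 3 actually lie from compound 1, since neither has a firm value, and whether the methyl at another place on this ring would give the same shift. Going by these compounds, it is also open whether a different group at this place, such as a methoxy, an amine or a carboxylic acid, would give a firm number or a lower one than compound 1.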